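The source may hold more compounds than are shown below. What is called first, only, known or untested is meant among the compounds shown, and "the series" means these compounds.

Compound 1 `CO[C@@H]1[C@H]2OC(=O)C[C@H]2O[C@@H]1[C@@H](O)c1ccccc1`: > 100000 nM
Compound 2 `CO[C@@H]1[C@H]2OC(=O)C[C@H]2O[C@@H]1[C@H](O)c1ccccc1`: > 100000 nM

In an ADME assay on MRC5 cells (Homo sapiens) for inhibition, read by MTT assay, with a stated time of 72 h (on this read-out lower numbers stand for stronger inhibition and higher numbers for weaker inhibition), compound 1 gives > 100000 nM, which is a limit of the assay and not a number. Compound 2 gives > 100000 nM, and this too is a limit. Together they describe (the limit of > 100000 nM in this assay, at which 2 of the 2 values shown sit), so the position of compound 1 is known only as a limit.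

Compound 3 `CO[C@@H]1[C@H]2OC(=O)C[C@H]2O[C@@H]1[C@@H](OC)c1ccccc1` comes from compound 1 by the change methyl in place of hydrogen on an oxygen on a saturated carbon: hydroxy to methoxy, with methyl in place of hydrogen on an oxygen on a saturated carbon.

Within the data shown here, the only measured step that bears on this is a step that the two limits leave unreadable from compound 1 to compound 2. Among the measured compounds shown here, that pair reflects (the fact that compounds 1 and 2 differ only in the configuration as drawn), and no measured step shows what adding methyl does. No step beyond the scatter, in either direction, is therefore expected in this assay. The estimated step is a number no higher from compound 1 to compound 3 (the limit leaves the size open). For compound 3 the expected value is 100000 nM, with an estimated range of 30000 nM to 300000 nM.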

Compound 3, half-maximal inhibitory concentration: 87600 nM
Estimate against measurement, compound 3: 1.1-fold (0.06 log units) above; the range from low to high includes it.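

Swapping hydroxy for methoxy at this position gives the only true number among the compounds shown in this assay: compound 3 reads 87600 nM. The change is recorded as an at least 1.1-fold lower number from compound 1 to compound 3 (0.05 log units; that floor lies within the scatter), so the methyl can be said to leave the number no higher, but no shift beyond the scatter can be claimed. The step has only a floor because compound 1 sits at a limit and not at a number: the limit of > 100000 nM in this assay, at which 2 of the 3 values shown sit.

Going by these compounds, the step between compound 1 and compound 2 cannot be read, so it stays open whether methoxy on the other drawn configuration would give a similar number. Also open, on these data alone, is how an ethoxy group, with its longer chain on this oxygen, or an amine in place of the hydroxy would read in this assay.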